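A Methyl on the Ring Nitrogen: Compound 3 to Compound 4

The source may report more compounds than this note shows. Statements on the series, on what has been measured and on what is new or still open speak of the compounds shown alone.

Three amidines on a shared core have been tested in a functional assay on PC-3 cells (Homo sapiens) for cytotoxicity, read by MTT assay, with a stated time of 72 h; a lower number here means a stronger inhibitor, a higher number a weaker inhibitor. Compound 1 `Cn1nc(-c2ccccc2)c2cc(C(=N)Nc3ccccc3)ncc21` gives 17300 nM. Compound 2 `CN1CCN(c2ccc(NC(=N)c3cc4cnn(C)c4cn3)cc2)CC1` gives 32300 nM. Compound 3 `CN1CCN(c2ccc(NC(=N)c3cc4c(-c5ccccc5)n[nH]c4cn3)cc2)CC1` gives 17100 nM. Compound 3 shows the lowest of the three numbers, yet its gap to compound 1 and its gap to compound 2 both fall within the usual scatter of repeated measurements, so no order among the three can be drawn from these values.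

Compound 4 `CN1CCN(c2ccc(NC(=N)c3cc4c(-c5ccccc5)nn(C)c4cn3)cc2)CC1` differs from compound 3 by methyl in place of hydrogen on an aromatic nitrogen. Within the data shown here, no measured pair differs only at this spot, so the size of this step has not been observed. Compound 1 and compound 2 each carry a methyl on that ring nitrogen, and their numbers in this assay lie in the same region as that of compound 3, which gives no sign of a shift beyond the scatter. The expected step is a 1.2-fold higher number from compound 3 to compound 4 (0.07 log units; within the scatter), a small move within the scatter, with no clear direction. Compound 4 is therefore estimated at 20000 nM, with a range from 8000 nM to 50000 nM.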

Compound 4, half-maximal inhibitory concentration: 5900 nM
Estimate against measurement, compound 4: 3.4-fold (0.53 log units) above; the measured number lies below the stated range.
By their numbers in this assay, from the lowest: compound 4; then compounds 3, 1 and 2 (each within the scatter of the next).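

In this assay, among these compounds, the methyl on the aromatic nitrogen gives the first observed step at this spot, a 2.9-fold lower number from compound 3 to compound 4 (0.46 log units; beyond the scatter), so one added carbon here is enough to move the number beyond the scatter. Compound 4 is also the only compound shown that carries the methyl, the phenyl and the 4-methylpiperazin-1-yl group together, and the other two changes also lead to it: phenyl in place of hydrogen on an aromatic carbon gives a 5.5-fold lower number from compound 2 to compound 4 (0.74 log units; beyond the scatter), and 4-methylpiperazin-1-yl in place of hydrogen on an aromatic carbon gives a 2.9-fold lower number from compound 1 to compound 4 (0.47 log units; beyond the scatter). Nothing at hand explains why these steps occur.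

Going by these compounds, whether an ethyl group or a longer chain on that ring nitrogen would lower the number further remains open. So does whether an amine on the chain would keep the step.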